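The compounds below may be only part of what the source reports. "The series", "measured", "known", "first", "only" and "open" are said of these compounds alone.

Going by the values given here, in an ADME assay on MT4 cells (Homo sapiens) for cytotoxicity, read by MTT assay, with a stated time of 5 days (a lower number here means that less compound is tolerated, a higher number that more compound is tolerated), compound 2 `Cc1cc(C)cc(S(=O)(=O)c2c(C(=O)N[C@H]3CCN(Cc4cccnc4)C3)[nH]c3ccc(Cl)cc23)c1` gives 22800 nM as the higher of the two numbers so far, and compound 1 `Cc1cc(C)cc(S(=O)(=O)c2c(C(=O)N[C@H]3CCNC3)[nH]c3ccc(Cl)cc23)c1` gives 10000 nM with only hydrogen on the ring nitrogen. Compound 3 `Cc1cc(C)cc(S(=O)(=O)c2c(C(=O)N[C@H]3CCN(S(C)(=O)=O)C3)[nH]c3ccc(Cl)cc23)c1` has methylsulfonyl in place of (pyridin-3-yl)methyl on an amine nitrogen in a ring and is otherwise the same as compound 2. Among the compounds with values here, the only measured step at that nitrogen was a 2.3-fold higher number from compound 1 to compound 2 (0.36 log units; beyond the scatter) and no methylsulfonyl case has been measured. In this assay a small move toward lower numbers is therefore expected, possibly inside the scatter, with a 1.5-fold lower number from compound 2 to compound 3 (0.18 log units; within the scatter) as the estimated step. For compound 3 the estimated value is 15000 nM and it is expected to fall between 6000 nM and 40000 nM in most repeats.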

Compound 3, half-maximal cytotoxic concentration: 29900 nM
Estimate against measurement, compound 3: 2.0-fold (0.30 log units) below; measured number inside the range.
By their numbers in this assay, from the lowest: compound 1; then compounds 2 and 3 (each within the scatter of the next).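

In this assay, methylsulfonyl in place of (pyridin-3-yl)methyl on the amine nitrogen in the ring gives a 1.3-fold higher number from compound 2 to compound 3 (0.12 log units; within the scatter) and so the two groups, one with an aromatic ring and one without, cannot be told apart here. Methylsulfonyl in place of hydrogen gives a 3.0-fold higher number from compound 1 to compound 3 (0.48 log units; beyond the scatter) and so two quite different groups on this nitrogen both give a higher number than hydrogen alone. Nothing available explains this result. The compounds shown leave open whether a plain methyl or an acetyl group on this nitrogen would also give a higher number than hydrogen, and whether a chain ending in a carboxylic acid would do the same.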